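The source may report more compounds than this note shows. Statements on the series, on what has been measured and on what is new or still open speak of the compounds shown alone.

Compound 1 `COc1cc(/C=C/C(=O)c2cccc(NC(=O)c3cccs3)c2)ccc1O` gives 3.98 ug/mL
Compound 2 `COc1cc(/C=C/C(=O)c2cccc(NC(=O)c3ccc(Cl)cc3)c2)ccc1O` gives 3.82 ug/mL
Compound 3 `COc1cc(/C=C/C(=O)c2cccc(NC(=O)c3ccco3)c2)ccc1O` gives 3.11 ug/mL

In a functional assay on Vero cells (Chlorocebus sabaeus) for inhibition (on this read-out lower numbers stand for stronger inhibition and higher numbers for weaker inhibition), compound 3 cannot be told apart from the other two, with a 1.3-fold lower number from compound 1 to compound 3 (0.11 log units; within the scatter) and a 1.2-fold lower number from compound 2 to compound 3 (0.09 log units; within the scatter) as its gaps. Compound 4 `COc1cc(/C=C/C(=O)c2cccc(NC(=O)C(C)C)c2)ccc1O` carries isopropyl in place of furan-2-yl on a carbonyl carbon. Three measured steps change the group at this same place: those two and a 1.0-fold lower number from compound 1 to compound 2 (0.02 log units; within the scatter) as well, all of them small. Among the compounds with values here, each swaps one ring for another, whereas here the ring is lost, and no measured compound shows that kind of change. No step beyond the scatter is therefore expected, though with limited confidence, and the expected size is a 1.3-fold higher number from compound 3 to compound 4 (0.11 log units; within the scatter) in this estimate. For compound 4 the estimated value in this assay is 4 ug/mL (expected range 1.8 ug/mL to 9 ug/mL).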

Compound 4, half-maximal inhibitory concentration: 3.47 ug/mL
Compound 4: middle estimate off by 1.2-fold (0.06 log units), on the high side; low and high end bracket the measured number.
By their numbers in this assay, from the lowest: compounds 3, 4, 2 and 1 (each within the scatter of the next).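

In this assay, a group with no ring, isopropyl, sits on this carbonyl carbon without any step beyond the scatter, whichever ring it replaces (a 1.1-fold higher number from compound 3 to compound 4 (0.05 log units; within the scatter)), (a 1.1-fold lower number from compound 2 to compound 4 (0.04 log units; within the scatter)) and (a 1.1-fold lower number from compound 1 to compound 4 (0.06 log units; within the scatter)). Among these four compounds, then, a ring at this place is not needed to keep the read-out in the same range, and neither is the hydrogen-bond acceptor that furan-2-yl brings. Nothing available explains why this position tolerates such different groups. Still open, as far as these compounds go, is whether an amine, a carboxylic acid or a longer chain here would produce a step beyond the scatter.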